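Fluoro to chloro swap on a second core

A few compounds are considered here, and "the series" means these few. Any claim that something is new, unique, unknown or untested is made for them only; others in the source may bear on it.

Compound 1 `COc1ccc(N/C=C\C(=O)c2cn(-c3ccccc3)nc2-c2ccc(F)cc2)cc1` gives 3200 nM in a functional assay on HT-29 cells (Homo sapiens) for antiproliferative activity, read by MTT assay, with a stated time of 48 h; a higher number here means a weaker inhibitor, a lower number a stronger inhibitor. Compound 2 `COc1ccc(N/C=C\C(=O)c2cn(-c3ccccc3)nc2-c2ccc(Cl)cc2)cc1` gives 8930 nM in this assay; the change from compound 1 to compound 2 is chloro in place of fluoro on an aromatic carbon and it made a step of a 2.8-fold higher number from compound 1 to compound 2 (0.45 log units; beyond the scatter). Compound 3 `COc1cc(-c2nn(-c3ccccc3)cc2C(=O)/C=C\Nc2ccc(F)cc2)cc(OC)c1OC` gives 12500 nM in this assay. The difference between the core of compound 3 and the core of compound 1 is not broken down here. Compound 4 `COc1cc(-c2nn(-c3ccccc3)cc2C(=O)/C=C\Nc2ccc(Cl)cc2)cc(OC)c1OC` is not yet measured; it differs from compound 3 by chloro in place of fluoro on an aromatic carbon, the same change as that from compound 1 to compound 2, at the same kind of place. By that precedent the expected step in this assay is a 2.0-fold higher number from compound 3 to compound 4 (0.30 log units; within the scatter), beside the earlier 2.8-fold higher number from compound 1 to compound 2 (0.45 log units; beyond the scatter), resting on one pair only. Compound 4 is estimated at 25000 nM, expected between 10000 nM and 60000 nM.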

Compound 4, half-maximal inhibitory concentration: 7680 nM
Beside the measured number, compound 4's estimate is 3.3-fold (0.51 log units) above it; measured number below the stated range.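

In this assay the change from 4-fluorophenyl to 4-chlorophenyl gives a 1.6-fold lower number from compound 3 to compound 4 (0.21 log units; within the scatter), so it does not separate these two compounds on this core. The step seen on the core of compound 1 did not carry over, and the two steps differ: the same change on two cores in this assay, a 2.8-fold higher number (0.45 log units; beyond the scatter) from compound 1 to compound 2 and a 1.6-fold lower number (0.21 log units; within the scatter) from compound 3 to compound 4, 4.5-fold (0.66 log units) apart, beyond the scatter of two such steps. Going by these compounds alone, with one pair per core, this shows only that the earlier step cannot be assumed to transfer; it does not show why, and the halogen in compound 3 sits in (4-fluorophenyl)amino, whereas compound 1 has methoxy on that ring, so core and site of the change cannot be told apart.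

Open, as far as these compounds go, is how bromo, methyl or a carboxylic acid in that place would read on either core. Also open, from the compounds shown here alone, is whether fluoro and chloro behave alike when each core carries the halogen on the same ring.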